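From Oxolane to a Carbon Bicycle at the Carbonyl

This account rests on a few compounds, and the source may have more. Where it says the series, first, only, none or still open, it means among the compounds named here.

Compound 1 `O=C(C1CCCO1)N1CC(c2nc(-c3cccc(Cl)c3)no2)C1` — > 10000 nM
Compound 2 `O=C(C1CCC(C(F)(F)F)CC1)N1CC(c2nc(-c3cccc(F)c3)no2)C1` — 680 nM

In an assay on HEK293 cells for positive allosteric modulation of metabotropic glutamate receptor 5 (Homo sapiens), read by FLIPR (on this read-out lower numbers stand for an effect already at smaller amounts and higher numbers for an effect only at larger amounts of compound), compound 1 gives > 10000 nM, which is a limit of the assay rather than a number, so compound 1 sits at the limit of > 10000 nM in this assay, at which 1 of the 2 values shown sits. Compound 2 gives 680 nM in this assay. Compound 3 `O=C([C@H]1CC2CCC1C2)N1CC(c2nc(-c3cccc(Cl)c3)no2)C1` differs from compound 1 in one place: a group of 7 heavy atoms (7 carbon; 2 five-membered non-aromatic rings of carbon only) in place of a group of 5 heavy atoms (4 carbon, 1 oxygen; one five-membered non-aromatic ring with 1 hetero atom), on a carbonyl carbon. Going by the values given here, no step between measured compounds is known, so the expectation rests on the change alone. The step from compound 1 to compound 3 is expected to move the effect toward smaller amounts, by an at least 3.3-fold lower number from compound 1 to compound 3 (0.52 log units; beyond the scatter). For compound 3 the estimate is 3000 nM, within 600 nM to 15000 nM.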

Compound 3, half-maximal effective concentration: 74 nM
Beside the measured number, compound 3's estimate is 41-fold (1.61 log units) above it; measured number outside the range, below it.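

At this place, on a carbonyl carbon whose other neighbours are an amide-type nitrogen in a ring, the group with 2 five-membered non-aromatic rings of carbon only in place of oxolan-2-yl gives, in this assay, an at least 130-fold lower number from compound 1 to compound 3 (2.13 log units; beyond the scatter). The step is large and beyond the scatter, so this place responds strongly to this change. The value of compound 1 is a limit of the assay, not a number: the limit of > 10000 nM in this assay, at which 1 of the 3 values shown sits.

The compounds shown leave open whether a single-ring cyclopentyl group would give a similar number at this carbonyl carbon. They also leave open how the mirror-image form of the group in compound 3 would read.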